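Series notes: urea to amide at the carbonyl carbon

This account rests on a few compounds, and the source may have more. Where it says the series, first, only, none or still open, it means among the compounds named here.

Of the compounds shown here, two have been measured. Compound 1 `O=C(Nc1cccc(-n2cc(-c3ccncc3)c(-c3cc(O)cc(Cl)c3)n2)c1)Nc1ccc(Cl)c(Cl)c1` gives 91% in a functional assay on ACHN cells (Homo sapiens) for inhibition, read by sulforhodamine B assay, with a stated time of 48 h, tested at 0.01 uM; a higher number here means a weaker effect of the compound at the concentration tested, a lower number a stronger effect; compound 2 `COc1cc(Cl)cc(-c2nn(-c3cccc(NC(=O)Nc4ccc(Cl)c(Cl)c4)c3)cc2-c2ccncc2)c1` gives 102% in this assay. Going by the values given here, the only measured step is a number 11 percentage points higher from compound 1 to compound 2 (beyond the scatter), and compound 2 therefore stands highest of the two numbers, with compound 1 the nearest.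

Compound 3 `COc1cc(Cl)cc(-c2nn(-c3cccc(NC(=O)c4cccc(C(F)(F)F)c4)c3)cc2-c2ccncc2)c1` is not yet measured. It differs from compound 2 by 3-(trifluoromethyl)phenyl in place of (3,4-dichlorophenyl)amino on a carbonyl carbon. Among the compounds with values here, no measured step touches the carbonyl carbon or the (3,4-dichlorophenyl)amino group; the one step that exists concerns the oxygen on an aromatic ring and so does not bear on this change. With both measured numbers close to the top of the scale, the step of a number 4 percentage points lower from compound 2 to compound 3 (within the scatter) is expected to be small, without a clear direction beyond the scatter. Compound 3 is accordingly estimated at 98% in this assay, within 80% to 115%.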

Compound 3, a percentage reported as activity, at one concentration (the size of the read-out at that concentration, not a potency): 98%
The estimate for compound 3 equals the measured number at the digits printed; measured number inside the range.
By their numbers in this assay, from the lowest: compounds 1, 3 and 2 (each within the scatter of the next, the first and the last beyond it).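

The carbonyl carbon now has its first measured step: 3-(trifluoromethyl)phenyl in place of (3,4-dichlorophenyl)amino gives a number 4 percentage points lower from compound 2 to compound 3 (within the scatter) in this assay. At this single concentration, the exchange removes the hydrogen-bond donor counted for the leaving group and both chlorine atoms, yet the read-out does not move beyond the usual scatter. Nothing measured here offers an explanation for this result.

As far as these compounds go, whether the two groups would separate at a higher concentration remains open, as does whether the hydroxyl-bearing ring of compound 1 would behave the same way with the 3-(trifluoromethyl)phenyl amide. A piperidine or a plain methyl group on the carbonyl carbon would show whether this position responds to anything other than an aromatic ring.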